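The source may report more compounds than this note shows. Statements on the series, on what has been measured and on what is new or still open speak of the compounds shown alone.

Three compounds share a common core built on a quinazolinone-like scaffold carrying a hydrazone-linked aromatic ring, and all three have been examined in a physicochemical assay, read by spectrophotometry, with a stated time of 15 min; a higher number here means a weaker inhibitor, a lower number a stronger inhibitor. Compound 1 `COc1cc(/C=N/NC(=O)CCCc2nc3ccccc3c(=O)[nH]2)cc(OC)c1OC` gives 85000000 nM. Compound 2 `COc1cc(/C=N/NC(=O)CCCc2nc3ccccc3c(=O)[nH]2)cc(OC)c1O` gives 225000000 nM. Compound 3 `O=C(CCc1nc2ccccc2c(=O)[nH]1)N/N=C/c1cc(O)c(O)c(O)c1` gives 45000000 nM, the lowest number of the three; its distance from compound 1 is within the usual scatter, while its distance from compound 2 is beyond it.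

One change among these is counted precisely. Between compound 2 and compound 1 the difference is methyl in place of hydrogen on an oxygen on an aromatic ring, and that change produced a 2.6-fold lower number from compound 2 to compound 1 (0.42 log units; beyond the scatter), a modest step beyond the scatter. The difference between the cores of compound 2 and compound 3 is not broken down here.

The unmeasured compound 4 `COc1cc(/C=N/NC(=O)CCc2nc3ccccc3c(=O)[nH]2)cc(O)c1O` differs from compound 3 by methyl in place of hydrogen on an oxygen on an aromatic ring, the same change, at a place described in the same words, that separates compound 2 from compound 1. Within the data shown here, only one earlier example of it exists, and that example and compound 3 start from different cores, so the comparison carries real uncertainty. Still, because compound 2 moved to compound 1 by a 2.6-fold lower number from compound 2 to compound 1 (0.42 log units; beyond the scatter), a similar modest step is expected here, estimated as a 2.3-fold lower number from compound 3 to compound 4 (0.35 log units; beyond the scatter). For compound 4 the expected value in this assay is therefore 20000000 nM, with a likely range from 6000000 nM to 60000000 nM.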

Compound 4, half-maximal inhibitory concentration: 50000000 nM
The estimate for compound 4 lay 2.5-fold (0.40 log units) below the measured number; the measured number falls inside the stated range.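

On the core of compound 3, swapping hydroxy for methoxy gave a 1.1-fold higher number from compound 3 to compound 4 (0.05 log units; within the scatter) in this assay and that step lies within the usual scatter, so this read-out cannot tell the two compounds apart, whereas the same swap on the core of compound 2 gave a 2.6-fold lower number from compound 2 to compound 1 (0.42 log units; beyond the scatter) and that step lies beyond the scatter. Among these compounds, the lower number seen on one core therefore did not carry over to the other, which shows that a step measured on one core was a poor guide to its size on a different core here, but with only one pair on each core this is a single contrast and not a rule for the series. No measurement shown here explains why the two steps differ.

The compounds shown leave open whether further pairs on each core would repeat this contrast, or whether a methyl placed on a different oxygen of the ring would read the same. They also leave open how a larger group on that oxygen, such as ethyl, or an amine in place of the hydroxy, would read in this assay on either core.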